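The source may hold more compounds than are shown below. What is called first, only, known or untested is meant among the compounds shown, and "the series" means these compounds.

Compounds 1, 2 and 3 share one core and differ only in the group on the aromatic carbon of the six-membered ring: compound 1 `CCCNc1nc(N)nc2c1ncn2/C=C1/CC1(CO)CO` carries propylamino, compound 2 `CCCSc1nc(N)nc2c1ncn2/C=C1/CC1(CO)CO` carries propylsulfanyl, and compound 3 `Nc1nc(SC2CCCC2)c2ncn(/C=C3/CC3(CO)CO)c2n1` carries cyclopentylsulfanyl. In an ADME assay on HFF cells (Homo sapiens) for cytotoxicity, with a stated time of 8 days (a higher number here means that more compound is tolerated, a lower number that less compound is tolerated), compound 1 gives > 300000 nM, which is a limit of the assay rather than a number. In this assay compound 2 gives > 300000 nM, again a limit. In this assay compound 3 gives > 300000 nM, also a limit. Because all three sit at the limit of > 300000 nM in this assay, at which 3 of the 3 values shown sit, the steps a step that the two limits leave unreadable from compound 1 to compound 2, a step that the two limits leave unreadable from compound 1 to compound 3 and a step that the two limits leave unreadable from compound 2 to compound 3 cannot be read in size or direction. Compound 3 therefore stands where every measured compound stands: at the limit, with nothing separating it from the others.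

Compound 4 `CCCCCCOc1nc(N)nc2c1ncn2/C=C1/CC1(CO)CO` is not yet measured. It differs from compound 3 in one place: hexyloxy in place of cyclopentylsulfanyl on an aromatic carbon

Within the data shown here, no measured step bears on this change, since none of the measured steps is readable. Given that compound 3 gives only a limit, compound 4 is expected to be tolerated to a similar extent, with an estimate of 400000 nM and a range from 150000 nM to 1500000 nM. The expected step that the limit leaves unreadable from compound 3 to compound 4 is thus estimated to lie within the scatter, most likely with only a limit reported again.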

Compound 4, half-maximal cytotoxic concentration: > 200000 nM
Compound 4 gave a limit, no number; the forecaster's own chance of this, stated with the estimate: 80%; the middle value lies beyond the limit too.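

In this assay compound 4 gives > 200000 nM, again a limit. Among these compounds, no step from compound 1, compound 2 or compound 3 to compound 4 can be read. The compounds shown leave open at what concentration any of the four harms the cells, and whether the group on the aromatic carbon matters for it.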